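The source may report more compounds than this note shows. Statements on the series, on what has been measured and on what is new or still open speak of the compounds shown alone.

Measured so far in an assay on CHO cells for displacement of a labelled ligand from adenosine receptor A1 (Homo sapiens), read by scintillation counting, with a stated time of 90 min, in the presence of a further agent that is not named here; a lower number here means a stronger inhibitor, a higher number a weaker inhibitor:

Compound 1, `CCCn1c(=O)[nH]c2nc(-c3ccc(S(=O)(=O)N4CCN(Cc5ccc(Br)cc5)CC4)cc3)[nH]c2c1=O`, gives > 1000 nM in this assay; this is a limit of the assay.
Compound 2, `CCCn1c(=O)[nH]c2nc(-c3ccc(S(=O)(=O)N4CCN(c5ccc(Br)cc5)CC4)cc3)[nH]c2c1=O`, gives > 1000 nM in this assay; this too is a limit.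
Compound 3, `CCCn1c(=O)[nH]c2nc(-c3ccc(S(=O)(=O)N4CCN(c5cccc(Cl)c5)CC4)cc3)[nH]c2c1=O`, gives > 1000 nM in this assay; again a limit.

Compound 1 therefore stands at the limit of > 1000 nM in this assay, at which 3 of the 3 values shown sit, with no number of its own. Within the data shown here, the three steps among the measured compounds, a step that the two limits leave unreadable from compound 1 to compound 2, a step that the two limits leave unreadable from compound 1 to compound 3 and a step that the two limits leave unreadable from compound 2 to compound 3, are all unreadable for the same reason, so the series so far carries no measured step that bears on the change to compound 4, `CCCn1c(=O)[nH]c2nc(-c3ccc(S(=O)(=O)N4CCN(Cc5ccc(Br)c(F)c5)CC4)cc3)[nH]c2c1=O`. The change is fluoro in place of hydrogen on an aromatic carbon. With every measured value sitting at the same limit, nothing in the data points to a step in either direction, and the expectation for this assay is no step beyond the scatter, with the most likely outcome another limit. Compound 4 is therefore estimated at 1500 nM, range 500 nM to 5000 nM, which means an expected step that the limit leaves unreadable from compound 1 to compound 4.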

Compound 4, inhibition constant: 326 nM
The estimate for compound 4 lay 4.6-fold (0.66 log units) above the measured number; the whole stated range lies above it.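

In this assay, among these compounds, fluoro on an aromatic carbon, ortho to a bromo group, is the first change to give a readable step, with an at least 3.0-fold lower number from compound 1 to compound 4 (0.48 log units; beyond the scatter). Compound 1 gives > 1000 nM, which is a limit, and the size of that step is therefore only a bound. Replacing 4-bromophenyl or 3-chlorophenyl with 4-bromo-3-fluorobenzyl gives an at least 3.0-fold lower number from compound 2 to compound 4 (0.48 log units; beyond the scatter) and an at least 3.0-fold lower number from compound 3 to compound 4 (0.48 log units; beyond the scatter), while the steps among the three earlier compounds cannot be read: the limit of > 1000 nM in this assay, at which 3 of the 4 values shown sit.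

Open, as far as these compounds go, is whether chloro, methyl or methoxy in place of fluoro at this position would also give a readable number. Also open, from the compounds shown here alone, are whether the same fluoro on the 4-bromophenyl of compound 2 would do so, and how a longer chain between the amine nitrogen and the aromatic ring would read.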